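Carboxymethyl amide in place of the diethylaminopropyl amide

The source may hold more compounds than are shown below. What is called first, only, known or untested is meant among the compounds shown, and "the series" means these compounds.

Within the data shown here, compound 2 `CCN(CC)CCCNC(=O)c1ccc(C(CC)(CC)c2ccc(OCC(O)C(C)(C)C)c(C)c2)n1CC` gives 2500 nM in a functional assay on PC-3 cells (Homo sapiens), read by MTT assay, with a stated time of 48 h (on this read-out lower numbers stand for stronger inhibition and higher numbers for weaker inhibition), the lowest of the two numbers so far; its nearest neighbour is compound 1 `CCn1c(C(=O)NCCCN(C)C)ccc1C(CC)(CC)c1ccc(OCC(O)C(C)(C)C)c(C)c1`, which gives 3100 nM in this assay, and the two lie within the scatter of each other. Compound 3 `CCn1c(C(=O)N(C)CC(=O)O)ccc1C(CC)(CC)c1ccc(OCC(O)C(C)(C)C)c(C)c1` differs from compound 2 by (carboxymethyl)(methyl)amino in place of (3-(diethylamino)propyl)amino on a carbonyl carbon. Among the measured compounds shown here, the only measured step, a 1.2-fold lower number from compound 1 to compound 2 (0.09 log units; within the scatter), exchanges one amine end of the chain for another and stays within the scatter, so it says nothing about removing the amine-bearing chain altogether; no measured step bears directly on the change to compound 3. With no guidance from the series, the expectation for compound 3 rests on the common core alone and is held wide. Compound 3 is estimated at 5000 nM in this assay, range 1500 nM to 20000 nM, a step of a 2.0-fold higher number from compound 2 to compound 3 (0.30 log units; within the scatter) toward a somewhat higher number.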

Compound 3, half-maximal inhibitory concentration: 23900 nM
Estimate against measurement, compound 3: 4.8-fold (0.68 log units) below; measured number outside the range, above it.
By their numbers in this assay, from the lowest: compounds 2 and 1 (each within the scatter of the next); then compound 3.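

At this carbonyl carbon, the end of the amide chain matters in this assay: exchanging one amine end for another gave only a 1.2-fold lower number from compound 1 to compound 2 (0.09 log units; within the scatter), whereas (carboxymethyl)(methyl)amino in place of (3-(diethylamino)propyl)amino gives a 9.6-fold higher number from compound 2 to compound 3 (0.98 log units; beyond the scatter), and in place of (3-(dimethylamino)propyl)amino gives a 7.7-fold higher number from compound 1 to compound 3 (0.89 log units; beyond the scatter). Both of these steps lie beyond the scatter, yet the replacement changes the chain, its end group and the methyl on the amide nitrogen at once, and neither step assigns the loss to one of them. No measurement shown bears on the reason for this difference.

Still open, from the compounds shown here alone, is whether the carboxylic acid, the shorter chain or the methyl on the amide nitrogen carries the step. A methyl on the amide nitrogen of the diethylamino chain, a propyl chain ending in a carboxylic acid, or one ending in a hydroxyl group would separate these.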